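The source may hold more compounds than are shown below. What is called first, only, known or untested is meant among the compounds shown, and "the series" means these compounds.

Measured compounds:
Compound 1 `Cn1ncc(Cl)c1-c1cc(C(=O)N[C@@H]2CN[C@H](CCO)C[C@H]2c2ccc(F)c(F)c2)oc1Cl`: 460 nM
Compound 2 `Cn1ncc(Cl)c1-c1cc(C(=O)N[C@@H]2CN[C@H](CCN3CCC(O)CC3)C[C@H]2c2ccc(Cl)c(Cl)c2)oc1Cl`: 15900 nM
Compound 3 `CNC(=O)C[C@@H]1C[C@@H](c2ccc(F)c(F)c2)[C@H](NC(=O)c2cc(-c3c(Cl)cnn3C)c(Cl)o2)CN1`: 800 nM

In a functional assay on OVCAR-8 cells (Homo sapiens) for antiproliferative activity (on this read-out lower numbers stand for stronger inhibition and higher numbers for weaker inhibition), compound 2 shows the highest of the three numbers; the nearest, compound 3, sits far lower, beyond the scatter, and compound 1 sits lower still, also beyond the scatter. The unmeasured compound 4 `Cn1ncc(Cl)c1-c1cc(C(=O)N[C@@H]2CN[C@H](CC(=O)NC3CCC3)C[C@H]2c2ccc(Cl)c(Cl)c2)oc1Cl` arises from compound 2 by one change: cyclobutylcarbamoyl in place of (4-hydroxypiperidin-1-yl)methyl on a saturated chain carbon bound to a saturated ring carbon. Among the compounds with values here, the only measured step at the same place is a 1.7-fold higher number from compound 1 to compound 3 (0.24 log units; within the scatter), where a carbamoyl chain replaced a hydroxymethyl without moving the number beyond the scatter. Within the data shown here, no measured step covers the loss of the (4-hydroxypiperidin-1-yl)methyl group itself; the values only show that compounds 1 and 3, which carry short chains at this carbon, give far lower numbers than compound 2. On that basis a lower number is expected for compound 4, though the size is uncertain. Compound 4 is estimated at 1500 nM, with a range from 300 nM to 8000 nM. This estimate means the expected step of an 11-fold lower number from compound 2 to compound 4 (1.03 log units; beyond the scatter).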

Compound 4, half-maximal inhibitory concentration: 610 nM
Beside the measured number, compound 4's estimate is 2.5-fold (0.39 log units) above it; the range from low to high includes it.
By their numbers in this assay, from the lowest: compounds 1, 4 and 3 (each within the scatter of the next); then compound 2.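

In this assay, within the data shown here, this position proves sensitive to what it carries: the change gives a 26-fold lower number from compound 2 to compound 4 (1.42 log units; beyond the scatter), whereas the only earlier step at this place, a 1.7-fold higher number from compound 1 to compound 3 (0.24 log units; within the scatter), stayed within the scatter. Unlike the gap between compound 2 and the earlier compounds, this step isolates the side chain, since compound 2 and compound 4 differ in that one place. It also shows that 2-(4-hydroxypiperidin-1-yl)ethyl gives a far higher number here than (cyclobutylcarbamoyl)methyl, though nothing shown explains the size of the step.

The change swaps the six-membered ring with its hetero atoms for a carbonyl and a four-membered carbon ring in one move, so the compounds shown do not tell which part carries the step. Also open, from the compounds shown here alone, is how a (piperidin-1-yl)carbonyl group, a simple primary amine or a carboxylic acid would read at this carbon in this assay.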